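The source may report more compounds than this note shows. Statements on the series, on what has been measured and on what is new or still open speak of the compounds shown alone.

Of the compounds shown here, three built on a shared core have been measured so far. In an assay on isolated protein for inhibition of Indoleamine 2,3-dioxygenase 1 (Homo sapiens), read by spectrophotometry (a lower number here means a stronger inhibitor, a higher number a weaker inhibitor), compound 1 `O=C(Cc1cccnc1)c1cc2c(O)cccc2[nH]1` gives 83000 nM. Compound 2 `O=C(Cc1cccnc1)c1cc2cc(Cl)ccc2[nH]1` gives 24600 nM in this assay, the lowest of the three numbers; its gap to compound 1 lies beyond the scatter, and its wider gap to compound 3 `CC(C(=O)c1cc2ccccc2[nH]1)c1cccnc1`, which gives 141000 nM, lies further beyond it. Compound 4 `O=C(Cc1cccnc1)c1cc2cc(OC(F)(F)F)ccc2[nH]1` has not yet been measured. It differs from compound 2 in a single place: trifluoromethoxy in place of chloro on an aromatic carbon. Among the compounds with values here, no two measured compounds differ in only one place, so no measured step can guide the expectation for this exchange; the three numbers show only that changes around the core of compound 2 can move the result in either direction by amounts beyond the scatter. The step is expected to be small, a 1.2-fold higher number from compound 2 to compound 4 (0.09 log units; within the scatter), lying within or only just beyond the scatter. Compound 4 is therefore estimated at 30000 nM in this assay, with a range from 10000 nM to 90000 nM.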

Compound 4, half-maximal inhibitory concentration: 13100 nM
The estimate for compound 4 lay 2.3-fold (0.36 log units) above the measured number; measured number inside the range.
By their numbers in this assay, from the lowest: compounds 4 and 2 (each within the scatter of the next); then compounds 1 and 3 (each within the scatter of the next).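

Within the data shown here, this is the first step that can be read at a single place: in this assay, a 1.9-fold lower number from compound 2 to compound 4 (0.27 log units; within the scatter) stays within the scatter, so chloro and trifluoromethoxy cannot be told apart on this aromatic carbon. Among these compounds, the exchange of 1 heavy atom for 5 heavy atoms, with 1 hydrogen-bond acceptor added, thus leaves the number within the scatter, something the earlier compounds, no two of which differed in only one place, could not show. Nothing given here bears on why the two groups read alike.

From the compounds shown here alone, whether an amine, a carboxylic acid or a longer alkyl chain on this aromatic carbon would also stay within the scatter remains open. So does whether the same exchange would read alike on another carbon of this six-membered ring.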